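The source may hold more compounds than are shown below. What is called first, only, known or untested is meant among the compounds shown, and "the series" means these compounds.

Going by the values given here, in a physicochemical assay for solubility, in phosphate buffer, measured as kinetic solubility, at pH 7.4 (on this read-out lower numbers stand for lower solubility and higher numbers for higher solubility), the three compounds measured so far on this shared core all return limits of the assay and no numbers. Compound 1 `Cc1oc(-c2c(F)cccc2F)nc1CN1CCC(C(=O)NCCCN2C[C@H](C)C[C@H](C)C2)CC1`, with its 2,6-difluorophenyl group, gives > 72 ug/mL, which is a limit. Compound 2 `Cc1cccc(F)c1-c1nc(CN2CCC(C(=O)NCCCN3C[C@H](C)C[C@H](C)C3)CC2)c(C)o1` gives > 72 ug/mL, also a limit. Compound 3 `COc1cccc(Cl)c1-c1nc(CN2CCC(C(=O)NCCCN3C[C@H](C)C[C@H](C)C3)CC2)c(C)o1`, with its 2-chloro-6-methoxyphenyl group, gives > 76 ug/mL, again a limit. Compound 3 thus stands alone at the limit of > 76 ug/mL in this assay, at which 1 of the 3 values shown sits. The other two stand together at the limit of > 72 ug/mL in this assay, at which 2 of the 3 values shown sit.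

Compound 4 `COc1cccc(C)c1-c1nc(CN2CCC(C(=O)NCCCN3C[C@H](C)C[C@H](C)C3)CC2)c(C)o1` has not yet been measured. It differs from compound 3 by methyl in place of chloro on an aromatic carbon, which turns 2-chloro-6-methoxyphenyl into 2-methoxy-6-methylphenyl. The closest measured change is a step that the two limits leave unreadable from compound 1 to compound 2, where methyl likewise takes the place of a halogen, fluoro. Also relevant are a step that the two limits leave unreadable from compound 1 to compound 3 and a step that the two limits leave unreadable from compound 2 to compound 3, both of which alter the same aromatic ring. None of these steps has a readable size, so they provide no measured shift to carry over, and no step beyond the scatter is expected in this assay. The expected change is a number no higher from compound 3 to compound 4 (the limit leaves the size open). For compound 4 the estimate is 76 ug/mL, with an expected range of 55 ug/mL to 105 ug/mL.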

Compound 4, solubility: > 73 ug/mL
Compound 4: only a limit was reported; the forecaster's own chance of this, stated with the estimate: 85%; the middle value is on the limit's open side.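

In this assay compound 4 gives > 73 ug/mL, which is a limit and not a number. Compound 1, compound 2 and compound 3 also return only limits, so none of the steps to compound 4 can be read. The compounds shown leave open where the actual solubility of each lies, and whether any of these changes on the aromatic ring shifts it.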